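Aryl variation on the azetidinone series: from compound 3 to compound 4

The source may report more compounds than this note shows. Statements on the series, on what has been measured and on what is new or still open speak of the compounds shown alone.

Compound 1 `COC(=O)/C(=C/c1ccccc1)CN1C(=O)[C@@H](OC)[C@H]1c1cccc([N+](=O)[O-])c1` gives 14400 nM in a functional assay on MDA-MB-231 cells (Homo sapiens) for antiproliferative activity, read by MTT assay, with a stated time of 48 h; on this read-out lower numbers stand for stronger inhibition and higher numbers for weaker inhibition. Compound 2 `COC(=O)/C(=C/c1ccccc1)CN1C(=O)[C@@H](OC)[C@H]1c1ccccc1C(F)(F)F` gives 17600 nM in the same assay; the change is a 1.2-fold higher number from compound 1 to compound 2 (0.09 log units; within the scatter), so the two aryl groups on the saturated ring carbon cannot be told apart on this read-out. Going by these compounds, compound 3 `COC(=O)/C(=C/c1ccccc1)CN1C(=O)[C@@H](OC)[C@H]1c1cccc(Cl)c1` carries 3-chlorophenyl at that position; in this assay compound 3 gives no result reported, so its standing among the measured compounds is unknown. Compound 4 `COC(=O)/C(=C/c1ccccc1)CN1C(=O)[C@@H](OC)[C@H]1c1ccc(Cl)cc1Cl` differs from compound 3 as follows: 2,4-dichlorophenyl in place of 3-chlorophenyl on a saturated ring carbon. Among the measured compounds shown here, the only measured step that bears on this kind of change, the exchange of one aryl group for another on the saturated ring carbon, is the one from compound 1 to compound 2, and it lay within the scatter. For the measured compounds named here, with no value for compound 3 and only that one small step to go on, no movement beyond the scatter is expected in this assay, and the number is expected to sit near the two measured values. For compound 4 the estimate in this assay is 15000 nM, within the range 5000 nM to 45000 nM.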

Compound 4, half-maximal inhibitory concentration: 19000 nM
For compound 4 the middle estimate is 1.3-fold (0.10 log units) below the measured one; the measured number falls inside the stated range.
By their numbers in this assay, from the lowest: compounds 1, 2 and 4 (each within the scatter of the next).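

In this assay, among the compounds shown here, the exchange for 2,4-dichlorophenyl on the saturated ring carbon gives a 1.1-fold higher number from compound 2 to compound 4 (0.03 log units; within the scatter) and a 1.3-fold higher number from compound 1 to compound 4 (0.12 log units; within the scatter) so three differently substituted aryl groups now stand together on this read-out, where the earlier compounds offered only one pair. Going by these compounds, the step from 3-chlorophenyl to 2,4-dichlorophenyl cannot be read, since compound 3 has no number, so the effect of adding the second chlorine on this ring stays unknown. No supporting data bear on this result.

Open, on these data alone, is whether an aryl group carrying an amine or a carboxylic acid at this position would move the number beyond the scatter. Also open, as far as these compounds go, is what a hydroxy group or a longer alkoxy chain in place of the methoxy group would do on the same core.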